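Two Methoxy Additions in a Cell Toxicity Series

A few compounds are considered here, and "the series" means these few. Any claim that something is new, unique, unknown or untested is made for them only; others in the source may bear on it.

Compound 1 `Cc1cc(C)cc(NC(=O)COc2cc(C)nc3ccccc23)c1` was tested in a toxicity assay on HepG2 cells (Homo sapiens) for inhibition, read by CellTiter-Glo, with a stated time of 48 h; a lower number here means a stronger inhibitor, a higher number a weaker inhibitor. In this assay compound 1 gives > 100000 nM, which is a limit of the assay rather than a number. Compound 2 `COc1ccc2c(OCC(=O)Nc3cc(C)cc(C)c3)cc(C)nc2c1` differs from it by methoxy in place of hydrogen on an aromatic carbon; in this assay compound 2 gives 50100 nM, a step of an at least 1.9-fold lower number from compound 1 to compound 2 (0.30 log units; that floor lies within the scatter). Compound 3 `COc1ccc2nc(C)cc(OCC(=O)Nc3ccc(Cl)c(OC)c3)c2c1` shares the core of compound 2; how its core differs from that of compound 1 is not broken down here. In this assay compound 3 gives > 100000 nM, again a limit. Compound 4 `COc1ccc2nc(C)cc(OCC(=O)Nc3cc(OC)c(Cl)cc3OC)c2c1` is not yet measured and differs from compound 3 by methoxy in place of hydrogen on an aromatic carbon, the same kind of change as before, but here the place is ortho to a large group, meta to a chloro group and para to a methoxy group, not part of a fused system. The series is marked by the limit of > 100000 nM in this assay, at which 2 of the 3 values shown sit. Since the earlier step was an at least 1.9-fold lower number from compound 1 to compound 2 (0.30 log units; that floor lies within the scatter) and compound 3 itself sits at a limit, the change is expected to amount to a number no higher from compound 3 to compound 4 (the limit leaves the size open). Compound 4 is expected to give about 100000 nM in this assay, most likely again only a limit.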

Compound 4, half-maximal inhibitory concentration in the HepG2 assay: > 100000 nM
Compound 4 was reported as a limit; the forecaster's own chance of this, stated with the estimate: 65%; the middle value lies on the limit itself.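

In the HepG2 assay compound 3 gives > 100000 nM as a limit. In the HepG2 assay compound 4 gives > 100000 nM as a limit too. The step between them cannot be read. The compounds shown leave open how strongly either one inhibits, and whether the added methoxy alters this. In a physicochemical assay for solubility, in phosphate buffer, measured as kinetic solubility, with a stated time of 1 h, at pH 7.4 (a higher number here means a more soluble compound, a lower number a less soluble compound), compound 3 gives 13000 nM and compound 4 gives 3000 nM with a step of a 4.3-fold lower number from compound 3 to compound 4 (0.64 log units; beyond the scatter) in this measurement.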